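Trading the indole of compound 2 for a fluorophenyl

The compounds below may be only part of what the source reports. "The series", "measured", "known", "first", "only" and "open" are said of these compounds alone.

Of the compounds shown here, three share one scaffold and have been tested in a functional assay on U-87MG ATCC cells (Homo sapiens) for cytotoxicity, read by MTT assay, with a stated time of 72 h; on this read-out higher numbers stand for weaker inhibition and lower numbers for stronger inhibition. Compound 1 `CN(C)CCn1cnnc1-c1cc(Oc2ccc(NC(=O)N/N=C/c3ccc(Cl)cc3Cl)cc2F)ccn1` gives 2330 nM. Compound 2 `CN(C)CCn1cnnc1-c1cc(Oc2ccc(NC(=O)N/N=C/c3c[nH]c4ccccc34)cc2F)ccn1` gives 690 nM, the lower of the two numbers on record. Compound 3 `Cn1ncnc1-c1cc(Oc2ccc(NC(=O)N/N=C/c3ccccc3)cc2F)ccn1`, which carries a different head group on the shared core, reaches only the limit of the assay at > 100000 nM. For the measured compounds named here, the one step between measured compounds, a 3.4-fold lower number from compound 1 to compound 2 (0.53 log units; beyond the scatter), describes a modest gain on going to the indole.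

Compound 4 `CN(C)CCn1cnnc1-c1cc(Oc2ccc(NC(=O)N/N=C/c3ccc(F)cc3)cc2F)ccn1` is the next compound to be tested. It differs from compound 2 in one place: 4-fluorophenyl in place of 1H-indol-3-yl on a carbon with a double bond to nitrogen. This change runs back toward a simpler aryl group, the direction opposite to the gain seen in the step from compound 1 to compound 2, so a loss of similar size is expected, with the halogenated phenyl of compound 1 as the closest point of reference. Compound 4 is therefore expected to give roughly 3000 nM in this assay, somewhere between 800 nM and 12000 nM, which would mean an expected step of a 4.3-fold higher number from compound 2 to compound 4 (0.64 log units; beyond the scatter).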

Compound 4, half-maximal inhibitory concentration: 2310 nM
The estimate for compound 4 lay 1.3-fold (0.11 log units) above the measured number, within the range that was stated.
By their numbers in this assay, from the lowest: compound 2; then compounds 4 and 1 (each within the scatter of the next). At a limit, above all of these: compound 3.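

In this assay, moving away from the indole on this carbon with a double bond to nitrogen costs activity even when the incoming phenyl carries only one fluorine, giving a 3.3-fold higher number from compound 2 to compound 4 (0.52 log units; beyond the scatter) in this single change. The two halogenated phenyl groups cannot be told apart, with a 1.0-fold lower number from compound 1 to compound 4 (0.00 log units; within the scatter) as the step between them, so among these three groups only 1H-indol-3-yl stands out. Nothing given here measures a property that would explain this difference.

The compounds shown leave open whether the indole's advantage depends on its hydrogen-bond donor or on its two-ring shape. A 1-methylindol-3-yl group, which keeps both rings without the hydrogen on nitrogen, and a naphthyl group, with two rings of carbon only, would separate these two possibilities.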